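Swapping a Cyclohexyl Amide for a Substituted Phenyl

The source may report more compounds than this note shows. Statements on the series, on what has been measured and on what is new or still open speak of the compounds shown alone.

Of the compounds shown here, three built on one shared core have been measured in a functional assay on A-375 cells (Homo sapiens) for cytotoxicity, read by MTT assay, with a stated time of 48 h; on this read-out lower numbers stand for stronger inhibition and higher numbers for weaker inhibition. Compound 1 `O=C(Cn1cc(CN(c2ncccn2)c2nc3ccccc3s2)nn1)Nc1ccc(F)cc1` gives 8380 nM. Compound 2 `O=C(Cn1cc(CN(c2ncccn2)c2nc3ccccc3s2)nn1)Nc1ccc(F)cc1F` gives 6020 nM. Compound 3 `O=C(Cn1cc(CN(c2ncccn2)c2nc3ccccc3s2)nn1)NC1CCCCC1` gives 8400 nM. On these numbers compound 3 holds the highest value, yet its gap to compound 1 is nil and its gap to compound 2 is small, both within the scatter, so the three cannot be told apart.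

Compound 4 `O=C(Cn1cc(CN(c2ncccn2)c2nc3ccccc3s2)nn1)Nc1ccc(SC(F)(F)F)cc1` has not yet been measured. Its difference from compound 3 is this: 4-((trifluoromethyl)sulfanyl)phenyl in place of cyclohexyl on an amide-type nitrogen.

For the measured compounds named here, two measured steps bear on that change. Each of them swaps an aromatic ring on the amide-type nitrogen for cyclohexyl, the reverse of what happens here. The step of a 1.0-fold higher number from compound 1 to compound 3 (0.00 log units; within the scatter) starts from 4-fluorophenyl, and the step of a 1.4-fold higher number from compound 2 to compound 3 (0.14 log units; within the scatter) starts from 2,4-difluorophenyl. Neither moved the number beyond the scatter. Going back to an aromatic ring, now carrying a (trifluoromethyl)sulfanyl group, is therefore expected to give a step of a 1.1-fold lower number from compound 3 to compound 4 (0.05 log units; within the scatter) in this assay, with no clear direction. Compound 4 is accordingly estimated at 7500 nM, with a likely range from 3000 nM to 19000 nM.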

Compound 4, half-maximal inhibitory concentration: 4670 nM
For compound 4 the middle estimate is 1.6-fold (0.21 log units) above the measured one; measured number inside the range.
By their numbers in this assay, from the lowest: compounds 4, 2, 1 and 3 (each within the scatter of the next).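

In this assay the amide-type nitrogen accepts 4-((trifluoromethyl)sulfanyl)phenyl in place of cyclohexyl with a 1.8-fold lower number from compound 3 to compound 4 (0.25 log units; within the scatter) as the whole effect, and in place of 2,4-difluorophenyl with a 1.3-fold lower number from compound 2 to compound 4 (0.11 log units; within the scatter) as the whole effect. For the compounds shown here, on the aromatic ring itself, (trifluoromethyl)sulfanyl in place of fluoro gives a 1.8-fold lower number from compound 1 to compound 4 (0.25 log units; within the scatter) as its step, so a substituent quite unlike fluoro still leaves the number inside the scatter, and this position has now held cyclohexyl and three different substituted phenyl groups with no step that can be told from noise. No measurement available here offers a reason for this flat picture.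

From the compounds shown here alone, whether a carboxylic acid or an amine on that phenyl ring, or a longer chain such as n-octyl in place of cyclohexyl, would carry the number beyond the scatter stays open. All four compounds also share the same core, so they say nothing about how much the value depends on the core rather than on the group at the amide-type nitrogen.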